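Dimethoxyphenyl regioisomer on the ester of compound 2

This account rests on a few compounds, and the source may have more. Where it says the series, first, only, none or still open, it means among the compounds named here.

Working notes. Compound 1 `COC(=O)c1cc(-n2cc(-c3cc(OC)cc(OC)c3)nn2)ccc1O` gives 3% in a functional assay on CCRF-CEM cells (Homo sapiens) for inhibition, read by MTT assay, with a stated time of 2 days, tested at 10 uM; a higher number here means more inhibition at the concentration tested (going by the name of the read-out), a lower number less inhibition. Compound 2 `COc1cc(OC)cc(-c2cn(-c3ccc(O)c(C(=O)OCCCc4ccccc4)c3)nn2)c1` gives 8% in this assay, and compound 3 `COc1cc(OC)cc(-c2cn(-c3ccc(O)c(C(=O)Nc4cccc(C(F)(F)F)c4)c3)nn2)c1` gives 73% in this assay. Compound 2 thus sits with compound 1, the step of a number 5 percentage points higher from compound 1 to compound 2 (within the scatter) being within the scatter, and lies far from compound 3, as a number 65 percentage points higher from compound 2 to compound 3 (beyond the scatter) shows; the step of a number 70 percentage points higher from compound 1 to compound 3 (beyond the scatter) points the same way. Both large steps concern only the group on the carbonyl carbon, while the remainder of the shared core is kept throughout.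

Compound 4 `COc1ccc(OC)c(-c2cn(-c3ccc(O)c(C(=O)OCCCc4ccccc4)c3)nn2)c1` differs from compound 2 by 2,5-dimethoxyphenyl in place of 3,5-dimethoxyphenyl on an aromatic carbon. Among the compounds with values here, none of the measured steps touches this part of the molecule; all three measured compounds carry the 3,5-dimethoxyphenyl. Within the data shown here, no measured step therefore bears on this change, and the value of compound 2 is the only anchor. No step beyond the scatter is expected in this assay in either direction. Compound 4 is expected at 10%, with a range from 0% to 30%. The estimated step of a number 2 percentage points higher from compound 2 to compound 4 (within the scatter) is expected to lie within the scatter.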

Compound 4, a percentage reported as inhibition, at one concentration (the size of the read-out at that concentration, not a potency): 5%
For compound 4 the middle estimate is 5 percentage points above the measured one, and the stated range covers the measured number.
By their numbers in this assay, from the lowest: compounds 1, 4 and 2 (each within the scatter of the next); then compound 3.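

In this assay, within the data shown here, 2,5-dimethoxyphenyl in place of 3,5-dimethoxyphenyl on the aromatic carbon of the five-membered ring gives a number 3 percentage points lower from compound 2 to compound 4 (within the scatter), the first reading on this position, since the earlier compounds all carry the 3,5-dimethoxyphenyl. With the 3-phenylpropoxy group on the carbonyl carbon, this rearrangement of the two methoxy groups therefore leaves the read-out within its usual scatter. Nothing measured here offers an explanation for this result.

From the compounds shown here alone, with compound 2 at only 8%, a loss from this change would be hard to see on the ester, so its effect in the presence of the (3-(trifluoromethyl)phenyl)amino group of compound 3 remains open. Also open, going by these compounds, is how this position would read with an amine or a carboxylic acid on the phenyl ring in place of the methoxy groups.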